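The compounds below may be only part of what the source reports. "The series", "measured", "known", "first", "only" and "open" are said of these compounds alone.

Measured so far:
compound 1, `CC(C)=C(C)C#Cc1ccc(CCC(=O)O)cc1`, gives 83.2 nM in a functional assay on 1321-N1 cells for agonist activity at Free fatty acid receptor 1 (Homo sapiens), read by calcium flux, with a stated time of 0.4 s; on this read-out lower numbers stand for an effect already at smaller amounts and higher numbers for an effect only at larger amounts of compound.
compound 2, `O=C(O)CCc1ccc(C#CC2(O)CCCCC2)cc1`, gives < 100000 nM in this assay, which is a limit of the assay rather than a number.
compound 3, `O=C(O)CCc1ccc(C#CCc2ccccc2)cc1`, gives 389 nM in this assay.

All three share the same core, a propanoic acid chain on a benzene ring that carries a triple bond; they differ only in what sits at the far end of that triple bond. Among the two compounds with a number, compound 1 has the lower one, and its nearest neighbour, compound 3, sits higher by a step beyond the usual scatter. For compound 2 only the limit is known (the limit of < 100000 nM in this assay, at which 1 of the 3 values shown sits).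

Compound 4, `C=C(C)C#Cc1ccc(CCC(=O)O)cc1`, has not been measured. It is compound 1 with 1-methylethenyl in place of 1,2-dimethylprop-1-en-1-yl on a triple-bonded carbon. Among the compounds with values here, since no pair of measured compounds shows this kind of trimming, the size of the step has to be guessed. The expected step from compound 1 to compound 4 is a 3.0-fold higher number from compound 1 to compound 4 (0.48 log units; beyond the scatter), a modest rise in the number, since the smaller group keeps the same kind of branched alkenyl end. Compound 4 is therefore estimated at 250 nM, with a likely range from 80 nM to 1000 nM.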

Compound 4, half-maximal effective concentration: 417 nM
Compound 4: middle estimate off by 1.7-fold (0.22 log units), on the low side; low and high end bracket the measured number.
By their numbers in this assay, from the lowest: compound 1; then compounds 3 and 4 (each within the scatter of the next).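

In this assay, within the data shown here, the swap of 1,2-dimethylprop-1-en-1-yl for 1-methylethenyl gives a 5.0-fold higher number from compound 1 to compound 4 (0.70 log units; beyond the scatter) as the first step that can be read at this position. Both groups have no ring, one double bond outside aromatic rings and no hydrogen-bond donors or acceptors, so the counted difference is size alone, 5 heavy atoms against 3 heavy atoms. Even so small a trim on this triple-bonded carbon moves the number beyond the usual scatter, so the carbons lost from compound 1 count for something here.

Nothing measured in this set explains the rise. Also open, going by these compounds, is whether a longer chain, a tert-butyl group or an amine on the same triple-bonded carbon would give a lower number than compound 1 or a higher one.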